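The source may report more compounds than this note shows. Statements on the series, on what has been measured and on what is new or still open speak of the compounds shown alone.

Measured so far in a functional assay on HEL cells (Homo sapiens); on this read-out higher numbers stand for lower toxicity in this test and lower numbers for higher toxicity in this test:
- Compound 1 `CCCCCCCCCc1cc2cn(COCCO)c(=O)nc2o1`: >= 100000 nM
- Compound 2 `CCCCCCc1cc2cn(COCCO)c(=O)nc2o1`: > 200000 nM

Neither entry is a true number. Compound 2 stands at > 200000 nM, which is a limit of the assay. Compound 1 stands at >= 100000 nM, and this too is a limit.

Compound 3 `CCCCCCCCc1cc2cn(COCCO)c(=O)nc2o1` differs from compound 2 in one place, with ethyl in place of hydrogen on a saturated chain carbon, six bonds along the chain from an aromatic carbon. Its chain is longer than that of compound 2 and shorter than that of compound 1.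

Among the measured compounds shown here, only one measured step bears on this change, a step that the two limits leave unreadable from compound 1 to compound 2. That step has no readable size, so the data give neither a size nor a direction for a change in chain length. With compound 3 lying between these two compounds in chain length, no step beyond the scatter is expected in this assay, and another limit is the likeliest report. The expected step is a number no higher from compound 2 to compound 3 (the limit leaves the size open). For compound 3 the estimated value is 200000 nM, with an expected range of 100000 nM to 300000 nM.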

Compound 3, half-maximal cytotoxic concentration: > 200000 nM
Compound 3: only a limit was reported (the forecaster's own chance of this, stated with the estimate: 80%); the middle value lies on the limit itself.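

In this assay compound 3 gives > 200000 nM, which is a limit of the assay and not a number. Among the compounds shown here, compound 1 and compound 2 are also reported only as limits, so no step among compound 1, compound 2 and compound 3 can be read. The compounds shown leave open whether chain length alters the cytotoxic concentration in this assay at all.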